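Methyl for methoxy on the core of compound 1

The compounds below may be only part of what the source reports. "The series", "measured", "known", "first", "only" and "open" are said of these compounds alone.

This account follows the shared core of compound 1 `COc1ccc2[nH]c(-c3ccc[nH]3)c(C3CC(=O)NC3=O)c2c1` as its methoxy group is exchanged. In a functional assay on MCF7 cells (Homo sapiens) for cytotoxicity, read by MTT assay, with a stated time of 72 h (on this read-out lower numbers stand for stronger inhibition and higher numbers for weaker inhibition), compound 1 gives 19000 nM, the lowest of the two numbers reported so far. For the measured compounds named here, its nearest neighbour is compound 2 `COc1ccc2[nH]c(-c3ccc[nH]3)cc2c1`, which in this assay gives 84000 nM; the only single-point step on record, a 4.4-fold higher number from compound 1 to compound 2 (0.65 log units; beyond the scatter), comes from hydrogen in place of 2,5-dioxopyrrolidin-3-yl on an aromatic carbon. A third entry, compound 3 `COc1ccc2[nH]c3c4cn[nH]c4c4c(c3c2c1)C(=O)NC4=O`, has no reported result in this assay ("not determined" (no result reported)).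

Compound 4 `Cc1ccc2[nH]c(-c3ccc[nH]3)c(C3CC(=O)NC3=O)c2c1` differs from compound 1 by methyl in place of methoxy on an aromatic carbon. Going by the values given here, no measured step touches this position: the step from compound 1 to compound 2 concerns a different part of the molecule and says nothing about the methoxy group. With nothing to draw on, no direction can be claimed, and the most defensible expectation is a step that stays within the scatter, the expected step being a 1.1-fold higher number from compound 1 to compound 4 (0.02 log units; within the scatter). Compound 4 is therefore estimated at 20000 nM in this assay, with a range from 6000 nM to 65000 nM to reflect the absence of any comparable change among the measured compounds.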

Compound 4, half-maximal inhibitory concentration: 29000 nM
The estimate for compound 4 lay 1.5-fold (0.16 log units) below the measured number, and the stated range covers the measured number.
By their numbers in this assay, from the lowest: compounds 1 and 4 (each within the scatter of the next); then compound 2.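

For the compounds shown here, the step of a 1.5-fold higher number from compound 1 to compound 4 (0.18 log units; within the scatter) is the first reading at this position of the shared core, and in this assay it shows that methyl can take the place of methoxy on this aromatic carbon without a change beyond the scatter. The oxygen and the hydrogen-bond acceptor counted on the methoxy group leave in this exchange, yet compound 1 and compound 4 cannot be ordered on this read-out, which sets this position apart from the 2,5-dioxopyrrolidin-3-yl position, where a 4.4-fold higher number from compound 1 to compound 2 (0.65 log units; beyond the scatter) lies beyond the scatter. No measured property accompanies this result, so nothing here explains why the exchange leaves the number within the scatter.

Methoxy and methyl are the only two groups compared at this carbon, so it remains open whether a hydroxyl, an amine, a chlorine or a longer chain such as ethoxy would also stay within the scatter or would move the number. Going by these compounds, it also remains open whether the methyl exchange would read the same way on compound 2, which lacks the 2,5-dioxopyrrolidin-3-yl group.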